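The compounds below may be only part of what the source reports. "The series", "measured", "known", "first", "only" and "open" are said of these compounds alone.

Measured so far in a functional assay on NCI-H23 cells (Homo sapiens) for cytotoxicity, read by sulforhodamine B assay, with a stated time of 48 h; on this read-out higher numbers stand for weaker inhibition of growth and lower numbers for stronger inhibition of growth:

Compound 1, `ClCc1ccc(Cn2cnc3c(Cl)ncnc32)cc1`: 660 nM
Compound 2, `ClCc1ccccc1Cn1cnc2c(Cl)ncnc21`: 2040 nM
Compound 3, `ClCc1cccc(Cn2cnc3c(Cl)ncnc32)c1`: 1900 nM

Compound 3 stands second highest of these three numbers. Compound 2 gives 2040 nM, which lies within the usual scatter of the number for compound 3, so nothing separates the two. Compound 1 gives 660 nM, a lower number that lies beyond the scatter, so compound 1 inhibits growth more strongly than compound 3.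

Compound 4, `ClCc1cccc(Cn2cnc3c(Cl)nc(Cl)nc32)c1`, has not been measured. It differs from compound 3 by chloro in place of hydrogen on an aromatic carbon. Among the measured compounds shown here, no pair among the measured compounds shows this change, so there is no measured precedent for its size. The step from compound 3 to compound 4 is expected to be a 1.3-fold lower number from compound 3 to compound 4 (0.10 log units; within the scatter), no larger than the scatter in either direction. Compound 4 is therefore expected to give about 1500 nM, between 500 nM and 4500 nM.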

Compound 4, concentration for 50% growth inhibition: 2130 nM
Estimate against measurement, compound 4: 1.4-fold (0.15 log units) below; measured number inside the range.
By their numbers in this assay, from the lowest: compound 1; then compounds 3, 2 and 4 (each within the scatter of the next).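

In this assay, swapping hydrogen for chloro on the aromatic carbon between two ring nitrogen atoms gives a 1.1-fold higher number from compound 3 to compound 4 (0.05 log units; within the scatter) and so makes no measurable difference. Among the compounds shown here, this position on compound 3 therefore takes a chloro with growth inhibition left unchanged, which the earlier compounds could not show. No measurement here offers an explanation for this.

Still open, from the compounds shown here alone, is whether an amine or a methoxy group at this position would leave the number just as unmoved. Also open, going by these compounds, is whether chloro here would do the same on compound 1.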